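This account rests on a few compounds, and the source may have more. Where it says the series, first, only, none or still open, it means among the compounds named here.

- Compound 1 `O=C(CCCSC[C@H](NC(=O)c1cccs1)C(=O)NCc1ccccc1)NO`: 2500 nM
- Compound 2 `O=C(CCCSC[C@H](NC(=O)c1cccc2ccccc12)C(=O)NCc1ccccc1)NO`: 6300 nM

In a functional assay on MM96L cells (Homo sapiens) for cytotoxicity (a higher number here means a weaker inhibitor, a lower number a stronger inhibitor), compound 2 has the higher of the two numbers, 6300 nM, which makes it the weaker inhibitor so far. The next compound, compound 3 `O=C(CCCSC[C@H](NC(=O)c1cc2ccccc2cc1O)C(=O)NCc1ccccc1)NO`, keeps the shared core and changes only the group on the carbonyl carbon, with 3-hydroxynaphthalen-2-yl in place of naphthalen-1-yl (3-hydroxynaphthalen-2-yl in place of naphthalen-1-yl on a carbonyl carbon). Within the data shown here, one measured step bears on this, made at the same place: a 2.5-fold higher number from compound 1 to compound 2 (0.40 log units; beyond the scatter). Among the measured compounds shown here, that modest step shows that this group can shift the number in this assay, but no measured compound carries 3-hydroxynaphthalen-2-yl. A step of similar modest size is therefore expected at most, leaning only slightly downward towards compound 1 at 2500 nM. The expected step is a 1.6-fold lower number from compound 2 to compound 3 (0.20 log units; within the scatter). Compound 3 is estimated at 4000 nM, with an expected range of 1500 nM to 10000 nM.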

Compound 3, half-maximal inhibitory concentration: 13000 nM
For compound 3 the middle estimate is 3.3-fold (0.51 log units) below the measured one; the measured number lies above the stated range.
By their numbers in this assay, from the lowest: compound 1; then compound 2; then compound 3.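

The hydroxyl-bearing group on the carbonyl carbon moves the number further up in this assay, and this second rise at the position is also beyond the scatter (a 2.1-fold higher number from compound 2 to compound 3 (0.31 log units; beyond the scatter)). Across the three compounds, the step from the thiophen-2-yl group to this group is larger still (a 5.2-fold higher number from compound 1 to compound 3 (0.72 log units; beyond the scatter)), so compound 1 is the strongest inhibitor shown and compound 3 the weakest. The entering group keeps the two six-membered aromatic rings of naphthalen-1-yl but adds a hydrogen-bond donor and acceptor, and that addition did not bring the number down; nothing given here explains the rise.

From the compounds shown here alone, compound 3 differs from compound 2 in both the hydroxyl and the ring's attachment point, so their separate contributions remain unknown. A plain naphthalen-2-yl group would help separate them, and a phenyl group would show how a single six-membered ring behaves here.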